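Ring Size at the Amide Nitrogen: Cyclopentyl to Cyclohexyl

The compounds below may be only part of what the source reports. "The series", "measured", "known", "first", "only" and "open" are said of these compounds alone.

Measured compounds:
- compound 1, `COc1cc2c(cc1OC)C(CC(=O)NC(C)(C)C)CC2`: 32%
- compound 2, `CCCCCCNC(=O)CC1CCc2cc(OC)c(OC)cc21`: 41.5%
- compound 3, `COc1cc2c(cc1OC)C(CC(=O)NC1CCCC1)CC2`: 52%

Three amides sharing one core were tested in a functional assay on the whole organism (strain Wistar) for inhibition, with Rattus norvegicus as the target, read by paw edema, with stated times of 60 min and 2 h, at a dose of 100 mg/kg by the oral route (on this read-out higher numbers stand for more inhibition at the one dose given (going by the name of the read-out) and lower numbers for less inhibition), differing only in the group on the amide-type nitrogen. Compound 3, with cyclopentyl, stands highest of the three: the step of a number 10.5 percentage points higher from compound 2 to compound 3 (beyond the scatter) and the step of a number 20 percentage points higher from compound 1 to compound 3 (beyond the scatter) both lie beyond the scatter, while the step of a number 9.5 percentage points higher from compound 1 to compound 2 (within the scatter) does not.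

Compound 4, `COc1cc2c(cc1OC)C(CC(=O)NC1CCCCC1)CC2`, has not yet been measured. It differs from compound 3 by cyclohexyl in place of cyclopentyl on an amide-type nitrogen. Among the compounds with values here, no measured step compares two rings of different size; the two steps that reach compound 3 show only that a ring on the nitrogen gave higher inhibition than the tert-butyl of compound 1 or the hexyl of compound 2. Going from one ring to a larger one, a step within the scatter is expected in this assay, with a slight lean upward. Compound 4 is therefore expected to show about 55%, between 40% and 68%, which means an expected step of a number 3 percentage points higher from compound 3 to compound 4 (within the scatter).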

Compound 4, a percentage reported as inhibition, in the whole organism at one dose (the size of the read-out at that dose, not a potency): 56%
Estimate against measurement, compound 4: 1 percentage points below; low and high end bracket the measured number.
By their numbers in this assay, from the lowest: compounds 1 and 2 (each within the scatter of the next); then compounds 3 and 4 (each within the scatter of the next).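

In this assay, within the data shown here, cyclohexyl in place of cyclopentyl on the amide-type nitrogen gives a number 4 percentage points higher from compound 3 to compound 4 (within the scatter), the first comparison of two rings at this position, and it does not tell the two ring sizes apart. Against the other two groups, the cyclohexyl amide shows a number 14.5 percentage points higher from compound 2 to compound 4 (beyond the scatter) and a number 24 percentage points higher from compound 1 to compound 4 (beyond the scatter), so among these four compounds both rings stand clear of the hexyl chain and the tert-butyl group. Nothing available here explains these differences.

The compounds shown leave open how a smaller cyclobutyl, a larger cycloheptyl or a phenyl ring on the same nitrogen would compare. They also leave open whether a ring containing oxygen, such as tetrahydropyranyl, would fit this picture, and, with only one dose, how the compounds rank in potency.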